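Swapping the Saturated Ring on a Shared Core

The compounds below may be only part of what the source reports. "The series", "measured", "known", "first", "only" and "open" are said of these compounds alone.

Compound 1, `NC(N)=NC(=O)c1nc(Cl)c(N2CCCC2)nc1N`, gives 84% in an assay for inhibition of acid-sensing ion channel 3 (Homo sapiens), read by patch clamp, tested at 20 uM; on this read-out higher numbers stand for more inhibition at the one concentration tested (going by the name of the read-out) and lower numbers for less inhibition. Compound 2, `NC(N)=NC(=O)c1nc(Cl)c(N2CCCCC2)nc1N`, gives 85%.

Compound 2 stands highest of the two numbers, but its nearest neighbour, compound 1, is separated from it only by a number 1 percentage points higher from compound 1 to compound 2 (within the scatter), which lies within the scatter. Compound 3, `CN1CCN(c2nc(N)c(C(=O)N=C(N)N)nc2Cl)CC1`, differs from compound 2 by 4-methylpiperazin-1-yl in place of piperidin-1-yl on an aromatic carbon. Among the measured compounds shown here, the one measured step, a number 1 percentage points higher from compound 1 to compound 2 (within the scatter), enlarged a saturated ring without moving the number beyond the scatter; no measured step adds a second ring hetero atom, so the expectation rests on compound 2 itself. Compound 3 is therefore expected near 76%, between 50% and 92%, an estimated step of a number 9 percentage points lower from compound 2 to compound 3 (within the scatter), with no change expected beyond the scatter.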

Compound 3, a percentage reported as inhibition, at one concentration (the size of the read-out at that concentration, not a potency): 51%
The estimate for compound 3 lay 25 percentage points above the measured number, within the range that was stated.
By their numbers in this assay, from the lowest: compound 3; then compounds 1 and 2 (each within the scatter of the next).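

The size of the saturated ring had not mattered at this position, but its make-up does: the change to 4-methylpiperazin-1-yl gives a number 34 percentage points lower from compound 2 to compound 3 (beyond the scatter) in this assay and a number 33 percentage points lower from compound 1 to compound 3 (beyond the scatter). Both steps are large, so the two earlier rings stand together against this one, which carries a second ring nitrogen and a methyl group. Nothing measured here explains the loss.

As far as these compounds go, whether the second nitrogen or its methyl group matters remains open. Plain piperazin-1-yl and morpholin-4-yl, with a ring oxygen instead, could help separate the two.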